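Amide nitrogen aryl swap in an antiproliferative series

The source may hold more compounds than are shown below. What is called first, only, known or untested is meant among the compounds shown, and "the series" means these compounds.

Three compounds of this series have been run in a functional assay on the whole organism (Ehrlich cells, Mus musculus) for antiproliferative activity, with a stated time of 24 h, at a dose of 0.2 mmol/kg by the intraperitoneal route; on this read-out lower numbers stand for less inhibition and higher numbers for more inhibition at the one dose given (going by the name of the read-out). Compound 1 `Nc1ccccc1NC(=O)c1ccc(NCC(=O)Nc2cccc([N+](=O)[O-])c2)cc1` gives 40.4% in this assay. Compound 2 `Nc1ccccc1NC(=O)CCCNCC(=O)Nc1cc(Cl)ccc1Cl` gives 50.9%, and compound 3 `COc1ccc(NC(=O)CNCCCC(=O)Nc2ccccc2N)cc1` gives 63.3%. On these numbers compound 1 stands lowest of the three: its nearest neighbour is compound 2, and the widest gap is to compound 3, both gaps lying beyond the scatter.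

Compound 4 `Nc1ccccc1NC(=O)c1ccc(NCC(=O)Nc2ccc(Cl)cc2)cc1` is the next member to be measured. Its difference from compound 1 is 4-chlorophenyl in place of 3-nitrophenyl on an amide-type nitrogen.

Among the compounds with values here, only one measured step bears on this change, and only loosely. The step of a number 12.4 percentage points higher from compound 2 to compound 3 (beyond the scatter) also swaps the aryl group on an amide-type nitrogen, but on a different core and with a different pair of aryl groups, so it shows that such a swap can move this assay by a modest amount without saying in which direction a nitro-to-chloro exchange would go. Within the data shown here, no compound in the set carries a 4-chlorophenyl on the amide-type nitrogen, so no direct anchor exists.

The expected step is therefore a number 4.6 percentage points higher from compound 1 to compound 4 (within the scatter), which is taken as none beyond the scatter, with a wide range to allow for a modest move either way. Compound 4 is estimated at 45%, between 28% and 62%.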

Compound 4, a percentage reported as inhibition, in the whole organism at one dose (the size of the read-out at that dose, not a potency): 73.3%
Compound 4: middle estimate off by 28.3 percentage points, on the low side, outside the stated range (above it).
By their numbers in this assay, from the lowest: compound 1; then compound 2; then compounds 3 and 4 (each within the scatter of the next).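

Within the data shown here, on the core of compound 1, the aryl group on an amide-type nitrogen proves to be a strong lever in this assay: a number 32.9 percentage points higher from compound 1 to compound 4 (beyond the scatter) is rated large, whereas the only earlier aryl swap on such a nitrogen, on another core, was the modest a number 12.4 percentage points higher from compound 2 to compound 3 (beyond the scatter). The change to 4-chlorophenyl from 3-nitrophenyl alters the substituent and its place on the ring together, so this one step cannot be assigned to either alone. No measurement at hand accounts for the size or direction of this step.

A 3-chlorophenyl and a 4-nitrophenyl on the same nitrogen of this core would separate the two parts of the change, and an unsubstituted phenyl would give a reference for both compound 1 and compound 4. Going by these compounds, it also remains open whether the 4-methoxyphenyl of compound 3 or the 2,5-dichlorophenyl of compound 2 would keep their order on the core of compound 1, and thus whether aryl effects carry over from one core to the other.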